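Aryl group on silicon: three measured, one pending

This account rests on a few compounds, and the source may have more. Where it says the series, first, only, none or still open, it means among the compounds named here.

Measured so far in a functional assay on liver (Sus scrofa) for inhibition of squalene monooxygenase (Homo sapiens), using microsomes; a higher number here means a weaker inhibitor, a lower number a stronger inhibitor:
compound 1, `CCN(C/C=C/C#CC(C)(C)C)Cc1cccc(OC[Si](C)(C)c2ccc(Cl)cc2)c1`, gives 400 nM;
compound 2, `CCN(C/C=C/C#CC(C)(C)C)Cc1cccc(OC[Si](C)(C)c2ccc(OC)cc2)c1`, gives 870 nM;
compound 3, `C=Cc1ccc([Si](C)(C)COc2cccc(CN(CC)C/C=C/C#CC(C)(C)C)c2)cc1`, gives 70 nM.

Compound 3 holds the lowest number of the three, with a 5.7-fold lower number from compound 1 to compound 3 (0.76 log units; beyond the scatter) and a 12-fold lower number from compound 2 to compound 3 (1.09 log units; beyond the scatter) both beyond the scatter. Compound 4, `CCN(C/C=C/C#CC(C)(C)C)Cc1cccc(OC[Si](C)(C)c2ccccc2-c2ccsc2)c1`, differs from compound 3 by 2-(thiophen-3-yl)phenyl in place of 4-vinylphenyl on a silicon. Within the data shown here, no measured step swaps the whole aryl group on silicon; the known steps only exchanged the substituent on an aromatic carbon, and both, a 2.2-fold higher number from compound 1 to compound 2 (0.34 log units; beyond the scatter) and a 12-fold lower number from compound 2 to compound 3 (1.09 log units; beyond the scatter), were modest to large. Replacing the vinyl-bearing ring, which gave the lowest number, is expected to move away from it. Compound 4 is therefore estimated at 300 nM, range 80 nM to 1200 nM, a step of a 4.3-fold higher number from compound 3 to compound 4 (0.63 log units; beyond the scatter), expected but uncertain.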

Compound 4, half-maximal inhibitory concentration: 10000 nM
Beside the measured number, compound 4's estimate is 33-fold (1.52 log units) below it; measured number outside the range, above it.
By their numbers in this assay, from the lowest: compound 3; then compound 1; then compound 2; then compound 4.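

In this assay the whole aryl group on silicon moves the number further than any substituent exchange did: a 140-fold higher number from compound 3 to compound 4 (2.15 log units; beyond the scatter) and an 11-fold higher number from compound 2 to compound 4 (1.06 log units; beyond the scatter) and also a 25-fold higher number from compound 1 to compound 4 (1.40 log units; beyond the scatter) are the steps to 2-(thiophen-3-yl)phenyl. So 4-vinylphenyl, 4-methoxyphenyl and 4-chlorophenyl all give lower numbers than this group, and the position does not treat these aryl groups alike. No available evidence bears on the cause of this loss. Still open, from the compounds shown here alone, is whether the loss follows the thiophen-3-yl ring itself or its place on the phenyl ring. Plain phenyl and 4-(thiophen-3-yl)phenyl on silicon would separate the two.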